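Alkoxy ether in place of ethyl on the shared core

The source may hold more compounds than are shown below. What is called first, only, known or untested is meant among the compounds shown, and "the series" means these compounds.

Of the compounds shown here, three have been measured in a physicochemical assay for permeability, using PAMPA; a higher number here means that the compound crosses the layer faster, a lower number that the compound crosses the layer more slowly. Compound 1 `Cc1ccnc([C@@H](C)Oc2cc3oc(=O)n(CCC(=O)O)c3cc2Cl)c1` gives < 3 nm/s, which is a limit of the assay and not a number, and so compound 1 sits at the limit of < 3 nm/s in this assay, at which 1 of the 3 values shown sits. Compound 2 `C[C@@H](Oc1cc2oc(=O)n(CCC(=O)O)c2cc1Cl)c1ccc(F)cn1` gives 31 nm/s. Going by the values given here, the only step between measured compounds that differ in one place is an at least 10-fold higher number from compound 1 to compound 2 (1.01 log units; beyond the scatter). Compound 3 `CCc1cc2oc(=O)n(CCC(=O)O)c2cc1Cl` gives < 10 nm/s, again a limit of the assay rather than a number, so compound 3 sits at the limit of < 10 nm/s in this assay, at which 1 of the 3 values shown sits. Compound 4 `O=C(O)CCn1c(=O)oc2cc(OCC3CCC3)c(Cl)cc21` differs from compound 3 in one place: cyclobutylmethoxy in place of ethyl on an aromatic carbon. The measured step concerns a different part of the molecule and does not bear directly on this change. Compound 2, which also carries an alkoxy group on the shared core, gives a number well above the limit at which compound 3 stands. On that basis, compound 4 is expected to give 25 nm/s, within 6 nm/s to 80 nm/s. The step of an at least 2.5-fold higher number from compound 3 to compound 4 (0.39 log units; beyond the scatter) is the expected outcome, upward and beyond the scatter.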

Compound 4, apparent permeability: 12 nm/s
For compound 4 the middle estimate is 2.1-fold (0.32 log units) above the measured one; the range from low to high includes it.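

Compound 3 stands at a limit of the assay and not at a number: (the limit of < 10 nm/s in this assay, at which 1 of the 4 values shown sits). With cyclobutylmethoxy in place of ethyl on this aromatic carbon, this assay gives a number for compound 4, and the step reads an at least 1.2-fold higher number from compound 3 to compound 4 (0.07 log units; that floor lies within the scatter) and so is only a floor, which leaves the true size of the change unknown. Compound 4 also shows that a number above the limits at this position does not depend on the 5-fluoropyridin-2-yl group of compound 2.

The compounds shown leave open how far the read-out follows the group at this position, as no simple methoxy or amine-bearing chain stands here. They also leave open what an ester or an amide in place of the carboxylic acid would do with cyclobutylmethoxy in place.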